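The source may hold more compounds than are shown below. What is called first, only, known or untested is meant among the compounds shown, and "the series" means these compounds.

- Compound 1 `COc1cc(C2=C(c3cc(C)c(OC)c(C)c3)C(O)CC2=O)cc(OC)c1OC`: > 100 ug/mL
- Compound 2 `COc1ccc(OC)c(C2=C(c3cc(OC)c(OC)c(OC)c3)C(=O)CC2O)c1`: > 100 ug/mL

In an ADME assay on HEK293 cells (Homo sapiens) for cytotoxicity, read by MTT assay, with a stated time of 72 h (on this read-out higher numbers stand for weaker inhibition and lower numbers for stronger inhibition), compound 1 gives > 100 ug/mL, which is a limit of the assay and not a number. Compound 2 gives > 100 ug/mL, which is also a limit. As far as these compounds go, compound 1 therefore stands at the limit of > 100 ug/mL in this assay, at which 2 of the 2 values shown sit, and its true value is unknown.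

Compound 3 `COc1cc(C2=C(c3cc(C)c(OC)c(C)c3)C(O[SiH2]C(C)(C)C)CC2=O)cc(OC)c1OC` has not yet been measured. It keeps the core of compound 1, and the change is a group of 5 heavy atoms (4 carbon, 1 silicon; no ring) in place of a hydrogen atom, on an oxygen on a saturated carbon. Within the data shown here, no pair of measured compounds shows what a change of this kind does here, so any expectation is loose. A modest move towards stronger inhibition, with a lower number in this assay, seems likely, although compound 3 may also end up reported only as a limit. The expected step is an at least 1.4-fold lower number from compound 1 to compound 3 (0.15 log units; that floor lies within the scatter). For compound 3 the estimated value is 70 ug/mL, with an expected range from 25 ug/mL to 200 ug/mL.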

Compound 3, half-maximal inhibitory concentration: 29 ug/mL
The estimate for compound 3 lay 2.4-fold (0.38 log units) above the measured number, and the stated range covers the measured number.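

In this assay, replacing the hydrogen atom on an oxygen on a saturated carbon with a group of 5 heavy atoms (4 carbon, 1 silicon; no ring) gives an at least 3.4-fold lower number from compound 1 to compound 3 (0.53 log units; beyond the scatter). This step lies beyond the usual scatter, and compound 3 is the first compound shown with a real number and not a limit, so a change at this oxygen can shift the read-out. The true size of the step remains unknown because the starting value for compound 1 is only a limit: the limit of > 100 ug/mL in this assay, at which 2 of the 3 values shown sit.

The compounds shown leave open whether the silicon matters or whether a methyl group, an acetyl group or a plain carbon chain on the same oxygen would give a similar step. Among these compounds, with only this one pair, they also leave open whether the same group would have a similar effect on compound 2.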